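This account rests on a few compounds, and the source may have more. Where it says the series, first, only, none or still open, it means among the compounds named here.

Measured so far:
- compound 1, `COc1ccccc1C[C@H]1COC(=O)[C@@H]1Cc1ccc(Cl)c(Cl)c1`, which in a functional assay on HL-60 cells (Homo sapiens) for cytotoxicity, read by WST assay, with a stated time of 48 h (on this read-out lower numbers stand for an effect already at smaller amounts and higher numbers for an effect only at larger amounts of compound), gives 14000 nM
- compound 2, `CCOc1ccccc1C[C@H]1COC(=O)[C@@H]1Cc1ccc(Cl)c(Cl)c1`, which in this assay gives 15000 nM
- compound 3, `COc1ccccc1C[C@H]1COC[C@@H]1Cc1ccc(Cl)c(Cl)c1`, which in this assay gives 55000 nM

Compound 1 and compound 2 share one core and differ by a single small change: methyl in place of hydrogen on a saturated chain carbon bound to an oxygen on an aromatic ring. In this assay this change made a step of a 1.1-fold higher number from compound 1 to compound 2 (0.03 log units; within the scatter), so the two numbers cannot be told apart with confidence.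

Compound 3 has a different core from compound 1, `COc1ccccc1C[C@H]1COC(=O)[C@@H]1Cc1ccc(Cl)c(Cl)c1`; the difference between the two cores is not broken down here. What the values show is that compound 3 stands at the highest number of the three, beyond the scatter from both compound 1 and compound 2.

Compound 4, `CCOc1ccccc1C[C@H]1COC[C@@H]1Cc1ccc(Cl)c(Cl)c1`, has not yet been measured. It differs from compound 3 by methyl in place of hydrogen on a saturated chain carbon bound to an oxygen on an aromatic ring, the same change in the same place as from compound 1 to compound 2. Because that earlier step was a 1.1-fold higher number from compound 1 to compound 2 (0.03 log units; within the scatter), the expectation for compound 4 is a step of about the same small size, a 1.1-fold higher number from compound 3 to compound 4 (0.02 log units; within the scatter), resting on one observed pair only. Compound 4 is therefore estimated to give 58000 nM in this assay, with a likely range from 30000 nM to 115000 nM.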

Compound 4, half-maximal effective concentration: 29000 nM
Beside the measured number, compound 4's estimate is 2.0-fold (0.30 log units) above it; the measured number lies below the stated range.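

In this assay the change from methoxy to ethoxy on the core of compound 3 gives a 1.9-fold lower number from compound 3 to compound 4 (0.28 log units; within the scatter) and so, like the earlier pair, these two compounds cannot be told apart with confidence. Set side by side, the two steps point in opposite directions on paper, but that gap is no larger than repeat measurements alone could produce: the same change on two cores in this assay, a 1.1-fold higher number (0.03 log units; within the scatter) from compound 1 to compound 2 and a 1.9-fold lower number (0.28 log units; within the scatter) from compound 3 to compound 4, 2.0-fold (0.31 log units) apart, within the scatter of two such steps. Within the data shown here, this shows that on these two cores the change from methoxy to ethoxy leaves a step too small to read, so the two cores give no sign of treating it differently, but with only two pairs it does not show that the steps are truly the same or that the change would stay this small on any other core.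

The compounds shown leave open whether a longer chain such as propoxy or butoxy, or a different group such as an amine or a carboxylic acid, in place of the methoxy would shift the number beyond the scatter. They also leave open whether a change of this kind elsewhere on the molecule, for instance on the ring that carries the two chlorines, would carry from one core to the other in the same way.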